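Compound 2 to compound 3: cyano gives way to an ester

The compounds below may be only part of what the source reports. "The series", "measured", "known", "first", "only" and "open" are said of these compounds alone.

In a functional assay on A549 cells (Homo sapiens) for inhibition, read by MTT assay, with a stated time of 72 h (a lower number here means a stronger inhibitor of growth, a higher number a weaker inhibitor of growth), compound 2 `CC1(C)CCC[C@]2(C)[C@@H](C=O)C(/C=C/C#N)=CC[C@@H]12` gives 27000 nM. For the measured compounds named here, its only measured neighbour, compound 1 `COC(=O)/C=C/C1=CC[C@H]2C(C)(C)CCC[C@]2(C)[C@H]1C=O`, gives 21000 nM, so the two stand level within the scatter. Compound 3 `C#CCCCOC(=O)/C=C/C1=CC[C@H]2C(C)(C)CCC[C@]2(C)[C@H]1C=O` shares their core, and the change is ((pent-4-yn-1-yl)oxy)carbonyl in place of cyano on a double-bonded chain carbon bound to a double-bonded chain carbon. In words, this is ((pent-4-yn-1-yl)oxy)carbonyl in place of cyano on a double-bonded chain carbon bound to a double-bonded chain carbon. Going by the values given here, one measured step bears on this place: a 1.3-fold higher number from compound 1 to compound 2 (0.11 log units; within the scatter), a swap of methoxycarbonyl for cyano that stayed within the scatter. Compound 3 carries an ester as compound 1 does, but no measurement shows what the pent-4-yn-1-yl chain does. No step beyond the scatter is therefore expected in this assay, and the estimated change is a 1.4-fold lower number from compound 2 to compound 3 (0.13 log units; within the scatter). For compound 3 the expected value is 20000 nM, with an estimated range of 8000 nM to 45000 nM.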

Compound 3, concentration for 50% growth inhibition: 30000 nM
Compound 3: the middle estimate sits 1.5-fold (0.18 log units) below what was measured; low and high end bracket the measured number.
By their numbers in this assay, from the lowest: compounds 1, 2 and 3 (each within the scatter of the next).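

In this assay, the step to the larger ester stays within the scatter, at a 1.1-fold higher number from compound 2 to compound 3 (0.05 log units; within the scatter), and so does the step from the small ester, at a 1.4-fold higher number from compound 1 to compound 3 (0.15 log units; within the scatter). This place on the shared core therefore takes ((pent-4-yn-1-yl)oxy)carbonyl, with 8 heavy atoms, in place of cyano, with 2, and the ester also takes but-3-yn-1-yl in place of hydrogen, with no readable shift in growth inhibition. No measurement offers an explanation for these level numbers.

On these data alone, it remains open whether a group of another kind at this place, such as an amine or a carboxylic acid, would move the number beyond the scatter. As far as these compounds go, it is equally open whether a still longer chain on the ester, or one without the triple bond, would leave it level.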